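Ring nitrogen swap on the aminomethyl heteroaryl side chain

The compounds below may be only part of what the source reports. "The series", "measured", "known", "first", "only" and "open" are said of these compounds alone.

Measured so far:
Compound 1 `CCC(C(=O)N[C@@H](CC(=O)O)C(=O)CSCc1ccccc1)n1ccnc(NCC2COc3ccccc3O2)c1=O` — 8220 nM
Compound 2 `CCC(C(=O)N[C@@H](CC(=O)O)C(=O)CSCc1ccccc1)n1ccnc(NCc2cc(C)no2)c1=O` — 3300 nM

Both compounds were tested in an assay for inhibition of Caspase-8 (Homo sapiens); on this read-out higher numbers stand for weaker inhibition and lower numbers for stronger inhibition. Among the compounds with values here, compound 1 gives 8220 nM and compound 2 gives 3300 nM, so compound 2 holds the lower of the two numbers; the only measured step, a 2.5-fold lower number from compound 1 to compound 2 (0.40 log units; beyond the scatter), separates them and lies beyond the scatter.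

Compound 3 `CCC(C(=O)N[C@@H](CC(=O)O)C(=O)CSCc1ccccc1)n1ccnc(NCc2nc(C)no2)c1=O` is not yet measured. It differs from compound 2 in one place: 3-methyl-1,2,4-oxadiazol-5-yl in place of 3-methyl-1,2-oxazol-5-yl on a saturated chain carbon bound to a nitrogen on an aromatic ring. Within the data shown here, the one measured step, a 2.5-fold lower number from compound 1 to compound 2 (0.40 log units; beyond the scatter), concerns a different exchange at the same place, a bicyclic saturated-fused ring for a five-membered aromatic ring, and it was modest. Among the measured compounds shown here, the change from compound 2 to compound 3 keeps a five-membered aromatic ring of the same size with a methyl on it, and only one ring carbon becomes a nitrogen, so nothing among the measured numbers points to a step beyond the scatter in either direction. The estimate for compound 3 in this assay is therefore 3500 nM, with a range from 1400 nM to 9000 nM, corresponding to an expected step of a 1.1-fold higher number from compound 2 to compound 3 (0.03 log units; within the scatter).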

Compound 3, half-maximal inhibitory concentration: 6420 nM
Estimate against measurement, compound 3: 1.8-fold (0.26 log units) below, within the range that was stated.
By their numbers in this assay, from the lowest: compounds 2, 3 and 1 (each within the scatter of the next, the first and the last beyond it).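

In this assay, the exchange of 3-methyl-1,2-oxazol-5-yl for 3-methyl-1,2,4-oxadiazol-5-yl on a saturated chain carbon bound to a nitrogen on an aromatic ring, which gives a five-membered aromatic ring with 3 hetero atoms in place of one with 2, amounts to a 1.9-fold higher number from compound 2 to compound 3 (0.29 log units; within the scatter), so this exchange does not separate the two compounds in this assay. Measured against 2,3-dihydro-1,4-benzodioxin-2-yl at the same place, 3-methyl-1,2,4-oxadiazol-5-yl gives a 1.3-fold lower number from compound 1 to compound 3 (0.11 log units; within the scatter), whereas 3-methyl-1,2-oxazol-5-yl gave a 2.5-fold lower number from compound 1 to compound 2 (0.40 log units; beyond the scatter), which shows that a five-membered aromatic ring at this place does not by itself set a compound apart from the 2,3-dihydro-1,4-benzodioxin-2-yl compound. No evidence is at hand that would explain these readings.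

From the compounds shown here alone, whether a phenyl ring or a carboxylic acid in place of the methyl on the five-membered aromatic ring would give a step beyond the scatter remains open. Going by these compounds, it is also open whether the readings at this place would hold with a different group elsewhere on the shared core.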